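The compounds below may be only part of what the source reports. "The series", "measured", "known", "first", "only" and "open" are said of these compounds alone.

Measured compounds:
compound 1, `COC(=O)Cn1cc(CNC(=O)c2cnc(Nc3ccc(C#N)cc3)cc2Oc2c(C)cc(C)cc2C)nn1`: 13800 nM
compound 2, `Cc1cc(C)c(Oc2cc(Nc3ccc(C#N)cc3)ncc2C(=O)NCc2cn(Cc3ccc([N+](=O)[O-])cc3)nn2)c(C)c1`: limit, >= 139000 nM
compound 3, `Cc1cc(C)c(Oc2cc(Nc3ccc(C#N)cc3)ncc2C(=O)NCc2cn(CC(=O)N3CCOCC3)nn2)c(C)c1`: 181000 nM

In an ADME assay on MT4 cells (Homo sapiens) for cytotoxicity, read by MTT assay, with a stated time of 5 days (a lower number here means that less compound is tolerated, a higher number that more compound is tolerated), compound 3 gives 181000 nM, the highest of the two numbers shown. Its nearest neighbour is compound 1, and the step of a 13-fold higher number from compound 1 to compound 3 (1.12 log units; beyond the scatter) lies beyond the scatter. For compound 2 the same assay reports only a limit, >= 139000 nM. The step that the limit leaves unreadable from compound 2 to compound 3 cannot be sized because of the limit of >= 139000 nM in this assay, at which 1 of the 3 values shown sits.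

Compound 4, `Cc1cc(C)c(Oc2cc(Nc3ccc(C#N)cc3)ncc2C(=O)NCc2cn(CCCO)nn2)c(C)c1`, differs from compound 3 in one place: 2-hydroxyethyl in place of (morpholin-4-yl)carbonyl on a saturated chain carbon bound to an aromatic nitrogen. The group that leaves is the one that entered in the step of a 13-fold higher number from compound 1 to compound 3 (1.12 log units; beyond the scatter), where the morpholin-4-yl in place of methoxy on a carbonyl carbon gave a large rise. For the measured compounds named here, compound 4 removes the whole (morpholin-4-yl)carbonyl and carries a 2-hydroxyethyl instead, a change smaller in atoms than either measured step and with no close precedent here. The step that the limit leaves unreadable from compound 2 to compound 3 gives no usable guidance. A modest downward step from compound 3 toward the level of compound 1 is expected, a 3.0-fold lower number from compound 3 to compound 4 (0.48 log units; beyond the scatter), with wide uncertainty. In this assay compound 4 is estimated at 60000 nM, within 15000 nM to 200000 nM.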

Compound 4, half-maximal cytotoxic concentration: 25200 nM
For compound 4 the middle estimate is 2.4-fold (0.38 log units) above the measured one; measured number inside the range.
By their numbers in this assay, from the lowest: compounds 1 and 4 (each within the scatter of the next); then compound 3.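

In this assay, a 7.2-fold lower number from compound 3 to compound 4 (0.86 log units; beyond the scatter) shows that, on a saturated chain carbon bound to an aromatic nitrogen, the high number of compound 3 is lost when 2-hydroxyethyl replaces (morpholin-4-yl)carbonyl. With a 1.8-fold higher number from compound 1 to compound 4 (0.26 log units; within the scatter), the exchange of methoxycarbonyl for 2-hydroxyethyl stays within the scatter, so among these four compounds the higher numbers go with the two ring-bearing groups, 4-nitrophenyl and (morpholin-4-yl)carbonyl, and no compound shown goes against this. The step of an at least 5.5-fold lower number from compound 2 to compound 4 (0.74 log units; beyond the scatter) starts from a value for compound 2 that is only a limit: the limit of >= 139000 nM in this assay, at which 1 of the 4 values shown sits.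

The step between compound 2 and compound 3 cannot be read. As far as these compounds go, whether a ring alone is enough stays open, and a morpholin-4-yl group on a plain chain without the carbonyl, a carboxylic acid or a longer hydroxyalkyl chain would bear on that.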